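A few compounds are considered here, and "the series" means these few. Any claim that something is new, unique, unknown or untested is made for them only; others in the source may bear on it.

Compound 1 `Cc1ccc(-c2nn(-c3ccccc3)cc2-c2nc3ccccc3[nH]2)cc1` gives 7260 nM in a functional assay on MCF7 cells (Homo sapiens) for antiproliferative activity, read by MTT assay, with a stated time of 24 h; on this read-out higher numbers stand for weaker inhibition and lower numbers for stronger inhibition.
Compound 2 `Cc1ccc(-c2nn(-c3ccccc3)cc2-c2nc3ccccc3n2S(=O)(=O)c2ccc(C)cc2)cc1` gives 570 nM in this assay.

Going by the values given here, of these two numbers compound 1 stands highest; its only neighbour lies at a 13-fold lower number from compound 1 to compound 2 (1.11 log units; beyond the scatter). Compound 3 `Cc1ccc(-c2nn(-c3ccccc3)cc2-c2nc3ccccc3n2S(=O)(=O)c2cc(C)ccc2C)cc1` differs from compound 1 by (2,5-dimethylphenyl)sulfonyl in place of hydrogen on an aromatic nitrogen. Among the compounds with values here, the single measured step that bears on this change is a 13-fold lower number from compound 1 to compound 2 (1.11 log units; beyond the scatter), a large drop, and the group entering in compound 3 closely resembles the (4-methylphenyl)sulfonyl that enters in compound 2. A drop of similar size is therefore expected. Compound 3 is expected to give about 700 nM, between 250 nM and 2000 nM. That estimate means an expected step of a 10-fold lower number from compound 1 to compound 3 (1.02 log units; beyond the scatter).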

Compound 3, half-maximal inhibitory concentration: 510 nM
Compound 3: middle estimate off by 1.4-fold (0.14 log units), on the high side, and the stated range covers the measured number.
By their numbers in this assay, from the lowest: compounds 3 and 2 (each within the scatter of the next); then compound 1.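

Going by these compounds alone, putting (2,5-dimethylphenyl)sulfonyl on the aromatic nitrogen also gives a large step (a 14-fold lower number from compound 1 to compound 3 (1.15 log units; beyond the scatter)), so the gain is not tied to the single sulfonyl group in compound 2. The step between the two sulfonyl compounds (a 1.1-fold lower number from compound 2 to compound 3 (0.05 log units; within the scatter)) shows that 2,5-dimethylphenyl in place of 4-methylphenyl on the sulfonyl sulfur makes no difference that stands out from the scatter. Nothing available explains these steps.

The compounds shown leave open whether the sulfonyl link itself matters, or whether a methyl or an acetyl on that nitrogen would give a similar number. They also leave open how a chlorine or a methoxy on the phenyl ring would read.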